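The source may report more compounds than this note shows. Statements on the series, on what has been measured and on what is new or still open speak of the compounds shown alone.

Compound 1, `C=C[C@@](C)(/C=C/c1ccc(O)cc1)CC/C=C/C(=O)OCC`. In a functional assay on Jurkat cells (Homo sapiens) for cytotoxicity, with a stated time of 72 h (a lower number here means that less compound is needed, a higher number that more compound is needed for the effect), compound 1 gives > 49000 nM, which is a limit of the assay.
Compound 2, `C=C[C@@](C)(/C=C/c1ccc(O)cc1)CC/C=C/C(=O)OCc1ccccc1`. In this assay compound 2 gives > 49000 nM, a limit of the assay.
Compound 3, `C=C[C@@](C)(/C=C/c1ccc(O)c(/C=C/C(=O)OCC)c1)CCC=C(C)C`. In this assay compound 3 gives > 49000 nM, again a limit of the assay.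

From compound 1 to compound 2 the change is phenyl in place of methyl on a saturated chain carbon bound to an oxygen next to a carbonyl group, and in this assay it gives a step that the two limits leave unreadable from compound 1 to compound 2. Within the data shown here, the only evidence on this step is the limit of > 49000 nM in this assay, at which 3 of the 3 values shown sit, so its size stays unknown.

Compound 4, `C=C[C@@](C)(/C=C/c1ccc(O)c(/C=C/C(=O)OCc2ccccc2)c1)CCC=C(C)C`, has not been measured. It differs from compound 3 by phenyl in place of methyl on a saturated chain carbon bound to an oxygen next to a carbonyl group, the same change as that from compound 1 to compound 2, at the same place. The difference between the two cores of compound 1 and compound 3 is not broken down here.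

Since compound 3 sits at a limit in this assay with > 49000 nM and the earlier step is unreadable, compound 4 is expected to show a step that the limit leaves unreadable from compound 3 to compound 4, most likely again only a limit. The estimate for compound 4 in this assay is 60000 nM, between 20000 nM and 200000 nM.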

Compound 4, half-maximal effective concentration: > 49000 nM
Compound 4 was reported as a limit; the forecaster's own chance of this, stated with the estimate: 85%; the middle value does not contradict the limit.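

In this assay compound 4 gives > 49000 nM, again a limit of the assay. Compound 3 also stands at a limit, so no step can be read between compound 3 and compound 4: the limit of > 49000 nM in this assay, at which 4 of the 4 values shown sit. The compounds shown leave open what concentration any of them would need for the effect, and whether phenyl in place of methyl changes it on either core.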